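This account rests on a few compounds, and the source may have more. Where it says the series, first, only, none or still open, it means among the compounds named here.

Of the compounds shown here, three sharing one core have been measured: compound 1 `COc1ccc(CNCCCNS(=O)(=O)c2cc(C(F)(F)F)cc(C(F)(F)F)c2)cc1OC`, compound 2 `O=S(=O)(NCCCNCC1COc2ccccc2O1)c1cc(C(F)(F)F)cc(C(F)(F)F)c1` and compound 3 `O=S(=O)(NCCCNCc1ccc(Cl)c(C(F)(F)F)c1)c1cc(C(F)(F)F)cc(C(F)(F)F)c1`. In a functional assay on ASPC1 cells (Homo sapiens) for inhibition, read by MTT assay, with a stated time of 72 h (a lower number here means a stronger inhibitor of growth, a higher number a weaker inhibitor of growth), compound 1 gives 6400 nM, compound 2 gives 2900 nM and compound 3 gives 9600 nM. Compound 3 thus has the highest number of the three, although the step of a 1.5-fold higher number from compound 1 to compound 3 (0.18 log units; within the scatter) stays within the scatter, while the step of a 3.3-fold higher number from compound 2 to compound 3 (0.52 log units; beyond the scatter) lies beyond it. Among the measured compounds shown here, the only place where these compounds differ is the group on the saturated chain carbon bound to an amine nitrogen.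

Compound 4 `COc1ccccc1CNCCCNS(=O)(=O)c1cc(C(F)(F)F)cc(C(F)(F)F)c1` changes that same place: 2-methoxyphenyl in place of 4-chloro-3-(trifluoromethyl)phenyl on a saturated chain carbon bound to an amine nitrogen. The measured steps that bear on this are a 2.2-fold lower number from compound 1 to compound 2 (0.34 log units; beyond the scatter) and a 3.3-fold higher number from compound 2 to compound 3 (0.52 log units; beyond the scatter), both modest, and a 1.5-fold higher number from compound 1 to compound 3 (0.18 log units; within the scatter), which shows that swapping one substituted phenyl ring for another can leave the number essentially unchanged. Compound 4 carries a methoxy group on its phenyl ring, as compound 1 does, so its number is expected to land near that of compound 1, giving an expected step of a 1.6-fold lower number from compound 3 to compound 4 (0.20 log units; within the scatter) in this assay, a change that may not rise beyond the scatter. The estimate for compound 4 is therefore 6000 nM, with a range from 2500 nM to 15000 nM.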

Compound 4, concentration for 50% growth inhibition: 4600 nM
Compound 4: the middle estimate sits 1.3-fold (0.12 log units) above what was measured; measured number inside the range.
By their numbers in this assay, from the lowest: compounds 2, 4, 1 and 3 (each within the scatter of the next, the first and the last beyond it).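

In this assay, among the compounds shown here, the step of a 2.1-fold lower number from compound 3 to compound 4 (0.32 log units; beyond the scatter) is the first beyond the scatter between two substituted phenyl rings at this place, on the saturated chain carbon bound to an amine nitrogen; the earlier comparison of two such rings stayed within it. Compound 4 nevertheless cannot be told apart from its other neighbours, since a 1.6-fold higher number from compound 2 to compound 4 (0.20 log units; within the scatter) and a 1.4-fold lower number from compound 1 to compound 4 (0.14 log units; within the scatter) both lie within the scatter, so 2-methoxyphenyl, 3,4-dimethoxyphenyl and 2,3-dihydro-1,4-benzodioxin-2-yl give numbers that this assay does not clearly separate from one another at each step. Nothing available here explains why 4-chloro-3-(trifluoromethyl)phenyl and 2-methoxyphenyl give different numbers.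

The compounds shown leave open whether the gain comes from the methoxy group entering or from the chlorine and trifluoromethyl group leaving, and a plain phenyl ring would be the natural comparison for separating the two. Also open, from the compounds shown here alone, is whether a hydroxyl group or a carboxylic acid on the phenyl ring, or a longer chain carrying that ring, would move the number beyond the scatter of these four compounds.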